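Adding isopropoxy to a weakly cytotoxic compound

The source may hold more compounds than are shown below. What is called first, only, known or untested is meant among the compounds shown, and "the series" means these compounds.

Compound 1 `OC(c1ccc(Cl)cc1)(c1cccnc1)c1ccccc1F`: > 100000 nM
Compound 2 `OC(c1ccc(Cl)cc1)(c1cccnc1)c1cccc(F)c1`: 66000 nM
Compound 3 `CC(C)Oc1ccccc1C(O)(c1ccc(Cl)cc1)c1cccnc1`: 48300 nM

These three compounds were tested in an ADME assay on L6 cells (Rattus norvegicus) for cytotoxicity, read by resazurin assay, with a stated time of 72 h; on this read-out higher numbers stand for weaker inhibition and lower numbers for stronger inhibition. Compound 1 stands at > 100000 nM, which is a limit of the assay and not a number. Compound 4 `CC(C)Oc1ccc(C(O)(c2ccc(Cl)cc2)c2cccnc2)c(F)c1` keeps the core of compound 1 and carries isopropoxy in place of hydrogen on an aromatic carbon, meta to a fluoro group and para to a large group (isopropoxy in place of hydrogen on an aromatic carbon).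

For the measured compounds named here, two measured steps bear on this change, and both give only a floor on their size. The closer guide is an at least 2.0-fold lower number from compound 1 to compound 3 (0.31 log units; beyond the scatter), where isopropoxy enters in place of fluoro. The other is an at least 1.5-fold lower number from compound 1 to compound 2 (0.18 log units; that floor lies within the scatter), where 3-fluorophenyl replaces 2-fluorophenyl and no isopropoxy is involved. Neither step places isopropoxy on the carbon it occupies in compound 4, so the expectation is loose. A modest move towards a lower number is expected, and the estimate is an at least 2.2-fold lower number from compound 1 to compound 4 (0.34 log units; beyond the scatter). For compound 4 the expected value in this assay is 45000 nM, with an estimated range of 20000 nM to 95000 nM.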

Compound 4, half-maximal inhibitory concentration: 58200 nM
Estimate against measurement, compound 4: 1.3-fold (0.11 log units) below; measured number inside the range.
By their numbers in this assay, from the lowest: compounds 3, 4 and 2 (each within the scatter of the next). At a limit, above all of these: compound 1.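

In this assay, isopropoxy on the aromatic carbon meta to the fluoro group and para to a large group gives an at least 1.7-fold lower number from compound 1 to compound 4 (0.23 log units; that floor lies within the scatter). Unlike the change to compound 3, where isopropoxy takes the place of fluoro, this change keeps the fluoro group, and compound 4 gives a measured number rather than a limit. Compound 1 stands at a limit and not a number, so the true size of this step cannot be read, and even its floor does not clear the usual scatter: the limit of > 100000 nM in this assay, at which 1 of the 4 values shown sits.

On these data alone, whether the drop in the number depends on isopropoxy itself stays open, since no other group on this carbon appears here, such as methoxy, an amine or a carboxylic acid. As far as these compounds go, it is also open whether isopropoxy on this carbon would give a similar step in a compound without the fluoro group.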